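A few compounds are considered here, and "the series" means these few. Any claim that something is new, unique, unknown or untested is made for them only; others in the source may bear on it.

Values in an ADME assay on HCT-116 cells (Homo sapiens) for antiproliferative activity (a lower number here means a stronger inhibitor, a higher number a weaker inhibitor), so far
compound 1 `Cc1cc(OCc2cccc(C#N)c2)ccc1Cl` gives 45000 nM
compound 2 `COc1ccc(C#N)cc1COc1ccc(Cl)c(C)c1` gives > 50000 nM (a limit of the assay, not a number)
compound 3 `COc1ccc(C(N)=O)cc1/C=C/c1ccc(Cl)cc1` gives 7100 nM

Compound 3 at 7100 nM holds the lower of the two actual numbers, with compound 1 higher by more than the scatter. The next change is fluoro in place of chloro on an aromatic carbon (fluoro in place of chloro on an aromatic carbon, para to a large group), which gives compound 4 `COc1ccc(C(N)=O)cc1/C=C/c1ccc(F)cc1`. For the measured compounds named here, the only measured step, an at least 1.1-fold higher number from compound 1 to compound 2 (0.04 log units; that floor lies within the scatter), is methoxy in place of hydrogen, with its floor within the scatter, and it involves no halogen. Going by the values given here, no measured step bears directly on this change, so the expectation rests on compound 3 at 7100 nM and no step beyond the scatter is expected in this assay in either direction. The expected step is a 1.1-fold higher number from compound 3 to compound 4 (0.05 log units; within the scatter) as estimated here. For compound 4 the estimated value is 8000 nM, with an expected range from 2800 nM to 23000 nM.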

Compound 4, half-maximal inhibitory concentration: 24000 nM
Compound 4: the middle estimate sits 3.0-fold (0.48 log units) below what was measured, outside the stated range (above it).
By their numbers in this assay, from the lowest: compound 3; then compounds 4 and 1 (each within the scatter of the next). At a limit, above all of these: compound 2.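

In this assay the group on this aromatic carbon, para to a large group, matters: fluoro in place of chloro gives a 3.4-fold higher number from compound 3 to compound 4 (0.53 log units; beyond the scatter), with chloro the better of the two halogens on the core of compound 3. For the compounds shown here, this is the first step read beyond the scatter, since the earlier methoxy step has only a floor within it. Nothing shown here accounts for the step.

On these data alone, whether bromo or an amine on this carbon would give a lower or higher number stays open. Also open, as far as these compounds go, is whether fluoro in place of chloro gives a similar step on the core of compound 1.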